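The source may report more compounds than this note shows. Statements on the series, on what has been measured and on what is new or still open speak of the compounds shown alone.

Compound 1, `CCn1nc(-c2ccnc(Nc3ccc(S(N)(=O)=O)cc3)n2)c2ccccc21`, gives 2050 nM in a functional assay on HCT-116 cells (Homo sapiens) for antiproliferative activity, read by MTT assay, with a stated time of 72 h; a lower number here means a stronger inhibitor of growth, a higher number a weaker inhibitor of growth.
Compound 2, `CCn1nc(-c2ccnc(Nc3ccc([N+](=O)[O-])cc3)n2)c2ccccc21`, gives 4060 nM in this assay.
Compound 3, `CCn1nc(-c2ccnc(Nc3ccc(O)cc3)n2)c2ccccc21`, gives 5290 nM in this assay.

Among these three, compound 1 carries the lowest number in this assay. Its nearest neighbour is compound 2, with a 2.0-fold higher number from compound 1 to compound 2 (0.30 log units; within the scatter), and its furthest is compound 3, with a 2.6-fold higher number from compound 1 to compound 3 (0.41 log units; beyond the scatter). Between the other two lies a 1.3-fold higher number from compound 2 to compound 3 (0.11 log units; within the scatter).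

Compound 4, `NS(=O)(=O)c1ccc(Nc2nccc(-c3nn(Cc4cccnc4)c4ccccc34)n2)cc1`, keeps the sulfamoyl-bearing aniline of compound 1 and changes only the group on the indazole nitrogen: pyridin-3-yl in place of methyl on a saturated chain carbon bound to an aromatic nitrogen. Among the measured compounds shown here, none of the measured steps touches this position; all three vary the substituent on the aniline ring while the ethyl stays fixed. For the measured compounds named here, the data therefore hold no direct precedent for the ethyl to (pyridin-3-yl)methyl change, and the expectation can only be anchored on compound 1 itself, with a wide band. Compound 4 is expected to give about 2000 nM in this assay, estimated between 600 nM and 7000 nM, that is a 1.0-fold lower number from compound 1 to compound 4 (0.01 log units; within the scatter), no step beyond the scatter being expected in either direction.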

Compound 4, concentration for 50% growth inhibition: 5130 nM
Compound 4: middle estimate off by 2.6-fold (0.41 log units), on the low side, within the range that was stated.
By their numbers in this assay, from the lowest: compounds 1, 2, 4 and 3 (each within the scatter of the next, the first and the last beyond it).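

Among the compounds shown here, the earlier compounds all kept the ethyl fixed, so this is the first reading at the place on a saturated chain carbon bound to an aromatic nitrogen: in this assay, pyridin-3-yl in place of methyl gives a 2.5-fold higher number from compound 1 to compound 4 (0.40 log units; beyond the scatter). The step is modest, so this place tolerates six heavy atoms and an aromatic ring entering for one carbon, yet this change does not lower the number. Nothing available here accounts for the rise.

A single change at this place cannot separate the pyridine nitrogen from the added ring, nor show whether the step would hold with nitro or hydroxy in place of sulfamoyl. From the compounds shown here alone, how a benzyl group, a longer chain or a chain ending in an amine would compare with the ethyl of compound 1 remains open.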